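This account rests on a few compounds, and the source may have more. Where it says the series, first, only, none or still open, it means among the compounds named here.

Compound 1, `CCC(=O)Oc1c(OC)c(OC)c(OC(=O)CC)c2ccccc12`, gives 3.44 in a physicochemical assay for lipophilicity; a lower number here means a more polar compound, a higher number a more lipophilic compound.
Compound 2, `CCCC(=O)Oc1c(OC)c(OC)c(OC(=O)CCC)c2ccccc12`, gives 4.64 in this assay.
Compound 3, `CCC(=O)Oc1c(OC)c(OC)c(OC(=O)CC)c2cc(Cl)ccc12`, gives 4.3 in this assay.

Compound 3 differs from compound 1 by chloro in place of hydrogen on an aromatic carbon, and that change produced a number 0.86 log units higher from compound 1 to compound 3 (beyond the scatter). Compound 2 carries a different core; the difference between the core of compound 2 and the core of compound 1 is not broken down here. Among the three measured compounds, compound 2 has the highest number, above compound 3 and further above compound 1.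

Compound 4, `CCCC(=O)Oc1c(OC)c(OC)c(OC(=O)CCC)c2cc(Cl)ccc12`, has not yet been measured in this assay. Among the measured compounds shown here, it differs from compound 2 by chloro in place of hydrogen on an aromatic carbon, the same change at the same place as the one that separates compound 1 from compound 3. Among the compounds shown this change occurs twice in all, once measured and once not, so the expectation rests on a single earlier pair. For the measured compounds named here, the step is expected to be a number 0.86 log units higher from compound 2 to compound 4 (beyond the scatter), because a number 0.86 log units higher from compound 1 to compound 3 (beyond the scatter) was seen for the one measured example. Compound 4 is therefore expected to give 5.5 in this assay, estimated to lie between 5.1 and 5.9.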

Compound 4, partition coefficient: 5.5
For compound 4 middle estimate and measured number coincide at the digits printed, within the range that was stated.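

In this assay chloro in place of hydrogen on an aromatic carbon gave a number 0.86 log units higher from compound 2 to compound 4 (beyond the scatter) and this matches a number 0.86 log units higher from compound 1 to compound 3 (beyond the scatter) in size, so the change carried from the core of compound 1 to the core of compound 2 without any shift in the step. The agreement rests on just two pairs, with the chloro at the same place in both, so it does not show that the step would hold on any other core or at any other place on the ring. Nothing shown here accounts for the match between the two steps.

The compounds shown leave open whether bromo or an amine at that same place would give a step of similar size, and whether the chloro step would persist with a longer chain or a carboxylic acid in place of the ester groups. They also leave open how this change would read out in any measurement other than this assay.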